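The compounds below may be only part of what the source reports. "The series", "measured", "known", "first", "only" and "open" are said of these compounds alone.

Working notes on the series. Within the data shown here, compound 2 `Cc1cccc(-c2cn3ccnc3c(-c3ccc4ncn(Cc5ccccc5)c4c3)n2)c1` has the lower of the two numbers measured so far: in a functional assay on RPMI-8226 cells (Homo sapiens) for inhibition, read by sulforhodamine B assay, with a stated time of 48 h, tested at 10 uM (a higher number here means more inhibition at the concentration tested (going by the name of the read-out), a lower number less inhibition), compound 2 gives 37.5%. Among the measured compounds shown here, its only neighbour, compound 1 `CCc1ccc(-c2cn3ccnc3c(-c3ccc4ncn(Cc5ccccc5)c4c3)n2)cc1`, gives 55.4% in this assay, and the single step measured, a number 17.9 percentage points lower from compound 1 to compound 2 (beyond the scatter), came from putting 3-methylphenyl in place of 4-ethylphenyl on an aromatic carbon.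

The next compound, compound 3 `O=Cc1ccc(-c2cn3ccnc3c(-c3ccc4ncn(Cc5ccccc5)c4c3)n2)cc1`, differs from compound 2 by 4-formylphenyl in place of 3-methylphenyl on an aromatic carbon. For the measured compounds named here, no measured step involves a 4-formylphenyl group, so the only guide is the step from compound 1 to compound 2, in which a 4-ethylphenyl group was worth a modest, beyond-scatter gain over 3-methylphenyl. Compound 3 returns to a 4-substituted phenyl, but with a formyl rather than an ethyl, and the two measured compounds give no information on that exchange. The expected step of a number 8.5 percentage points higher from compound 2 to compound 3 (within the scatter) is therefore a small rise, with wide uncertainty. For compound 3 the estimate in this assay is 46%, within 22% to 70%.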

Compound 3, a percentage reported as inhibition, at one concentration (the size of the read-out at that concentration, not a potency): 82.5%
Compound 3: middle estimate off by 36.5 percentage points, on the low side; the whole stated range lies below it.
By their numbers in this assay, from the lowest: compound 2; then compound 1; then compound 3.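

At this position on the shared core, the phenyl substituent can move the result much further than the first step suggested: in this assay the change to 4-formylphenyl gives a number 45 percentage points higher from compound 2 to compound 3 (beyond the scatter). The comparison of 4-ethylphenyl with 4-formylphenyl changes only the group on the phenyl ring, and formyl in place of ethyl still gives a number 27.1 percentage points higher from compound 1 to compound 3 (beyond the scatter), so having a 4-substituted phenyl does not alone set the number; the identity of the substituent matters as well. Nothing available here accounts for the size of either step.

The compounds shown do not separate the choice of substituent from its placement on the phenyl ring, since compound 2 differs from compound 1 and compound 3 in both, and a 3-formylphenyl or 4-methylphenyl group would be needed to pull those two apart. On these data alone, it also remains open whether the high number is specific to the formyl group or extends to an acetyl, a hydroxymethyl or a carboxylic acid in its place, and these single-concentration readings give no measure of potency.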